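The compounds below may be only part of what the source reports. "The series", "measured", "known", "first", "only" and "open" are said of these compounds alone.

Measured in a functional assay on B16-F10 cells (Mus musculus) for antiproliferative activity, read by MTT assay, with a stated time of 48 h; a lower number here means a stronger inhibitor, a higher number a weaker inhibitor:
- compound 1 `CC(=O)N1N=C(c2ccccc2)CC1c1ccc2c(c1)OCCO2`: 39500 nM
- compound 2 `CC(=O)N1N=C(c2ccc(F)cc2)CC1c1ccc2c(c1)OCCO2`: 53100 nM
- compound 3 `CC(=O)N1N=C(c2ccc(Cl)cc2)CC1c1ccc2c(c1)OCCO2`: 47300 nM

Compound 3 cannot be separated from the other two compounds in this assay. Its value lies within the scatter of both neighbours, as shown by the step of a 1.1-fold lower number from compound 2 to compound 3 (0.05 log units; within the scatter) and the step of a 1.2-fold higher number from compound 1 to compound 3 (0.08 log units; within the scatter). The remaining step, a 1.3-fold higher number from compound 1 to compound 2 (0.13 log units; within the scatter), also stays within the scatter, so the three values show no order.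

Next in the series is compound 4 `CC(=O)N1N=C(c2ccc(Br)cc2)CC1c1ccc2c(c1)OCCO2`, which has bromo in place of chloro on an aromatic carbon, para to a large group (bromo in place of chloro on an aromatic carbon). Among the compounds with values here, no bromo compound has been measured, so the evidence is indirect. Within the data shown here, the closest precedent is the exchange of one halogen for another, the step of a 1.1-fold lower number from compound 2 to compound 3 (0.05 log units; within the scatter). Adding a halogen to the unsubstituted ring also gave only small steps, a 1.3-fold higher number from compound 1 to compound 2 (0.13 log units; within the scatter) and a 1.2-fold higher number from compound 1 to compound 3 (0.08 log units; within the scatter).

On these three steps, no change beyond the scatter is expected in this assay, and no direction can be assigned. The expected step is a 1.1-fold lower number from compound 3 to compound 4 (0.02 log units; within the scatter). Compound 4 is estimated at 45000 nM, with an expected range from 23000 nM to 78000 nM.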

Compound 4, half-maximal inhibitory concentration: 44100 nM
Estimate against measurement, compound 4: 1.0-fold (0.01 log units) above, within the range that was stated.
By their numbers in this assay, from the lowest: compounds 1, 4, 3 and 2 (each within the scatter of the next).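

Working notes: in this assay, bromo in place of chloro gives a 1.1-fold lower number from compound 3 to compound 4 (0.03 log units; within the scatter), so the exchange of 4-chlorophenyl for 4-bromophenyl extends the earlier halogen exchange to a third halogen without producing a separable difference. The comparisons with the other two compounds read the same way, with a 1.2-fold lower number from compound 2 to compound 4 (0.08 log units; within the scatter) and a 1.1-fold higher number from compound 1 to compound 4 (0.05 log units; within the scatter), so hydrogen, fluoro, chloro and bromo on this aromatic carbon, para to a large group, now form a set of four compounds with no order among them and the earlier absence of a halogen effect no longer rests on fluoro and chloro alone. No measurement is available that would explain this lack of separation.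

On these data alone, whether anything other than hydrogen or a single halogen atom at this place would move the number beyond the scatter remains open, for example an amine, a carboxylic acid or a longer alkyl chain. As far as these compounds go, the acetyl group and the rest of the shared core are identical in all four compounds, so the response of the number to a change in those parts also remains unknown.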